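Swapping fluoro for methoxy on the fused ring of compound 3

The compounds below may be only part of what the source reports. "The series", "measured", "known", "first", "only" and "open" are said of these compounds alone.

Measured so far:
compound 1 `COc1ccc2nc(NC(=O)c3cn(-c4ccccc4)nc3-c3ccc(F)cc3)sc2c1`: 33200 nM
compound 2 `O=C(Nc1nc2ccccc2s1)c1cn(-c2ccccc2)nc1-c1ccc(Cl)cc1`: 13700 nM
compound 3 `O=C(Nc1nc2ccc(F)cc2s1)c1cn(-c2ccccc2)nc1-c1ccc(Cl)cc1`: 4970 nM

All three were tested in a functional assay on HT-29 cells (Homo sapiens) for cytotoxicity, read by MTT assay, with a stated time of 72 h; on this read-out lower numbers stand for stronger inhibition and higher numbers for weaker inhibition. Compound 3 gives the lowest number of the three; compound 2 stands nearest, and compound 1 furthest. For the measured compounds named here, the one single-point step available is a 2.8-fold lower number from compound 2 to compound 3 (0.44 log units; beyond the scatter), which concerns the same aromatic carbon of the fused ring that is changed here.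

Compound 4 `COc1ccc2nc(NC(=O)c3cn(-c4ccccc4)nc3-c3ccc(Cl)cc3)sc2c1` is not yet measured. It differs from compound 3 by methoxy in place of fluoro on an aromatic carbon. Going by the values given here, no measured pair shows fluoro against methoxy at this carbon, so the step itself is untested. Compound 1, which also carries methoxy there but with a different halogen on the other ring, gives 33200 nM, the highest number of the set. Taking that together with the modest gain seen in a 2.8-fold lower number from compound 2 to compound 3 (0.44 log units; beyond the scatter), the number for compound 4 is expected to rise, giving an estimated 3.0-fold higher number from compound 3 to compound 4 (0.48 log units; beyond the scatter). Compound 4 is thus estimated at 15000 nM, with a range from 5000 nM to 45000 nM.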

Compound 4, half-maximal inhibitory concentration: 18600 nM
For compound 4 the middle estimate is 1.2-fold (0.09 log units) below the measured one; low and high end bracket the measured number.
By their numbers in this assay, from the lowest: compound 3; then compounds 2, 4 and 1 (each within the scatter of the next, the first and the last beyond it).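

In this assay, the direct comparison of fluoro with methoxy on this aromatic carbon gives a 3.7-fold higher number from compound 3 to compound 4 (0.57 log units; beyond the scatter), so the gain seen with fluoro does not carry over to methoxy. Methoxy and hydrogen at this carbon cannot be told apart, at a 1.4-fold higher number from compound 2 to compound 4 (0.13 log units; within the scatter), which leaves fluoro as the only one of the three groups that stands clear of the others in this series. With methoxy held in place, chloro in place of fluoro on an aromatic carbon gives a 1.8-fold lower number from compound 1 to compound 4 (0.25 log units; within the scatter), so this swap does not separate those two compounds.

No measured evidence here explains why fluoro stands apart from methoxy and hydrogen at this carbon. On these data alone, whether an amine or a carboxylic acid at this carbon would pattern with fluoro or with methoxy remains open.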